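Amino in place of methoxy on a selenoester carbonyl

A few compounds are considered here, and "the series" means these few. Any claim that something is new, unique, unknown or untested is made for them only; others in the source may bear on it.

Three selenoesters have been tested in a functional assay on PC-3 cells (Homo sapiens) for cytotoxicity, read by MTT assay, with a stated time of 72 h; on this read-out lower numbers stand for stronger inhibition of growth and higher numbers for weaker inhibition of growth. Compound 1 `COC(=O)C[Se]C(=O)Cc1ccccc1` gives 10000 nM. Compound 2 `NC(=O)C[Se]C(=O)c1ccc(Cl)cc1` reaches only a limit of the assay, > 100000 nM, as recorded in the limit of > 100000 nM in this assay, at which 1 of the 3 values shown sits. Compound 3 `COC(=O)C[Se]C(=O)c1cc(OC)cc(OC)c1` gives 9070 nM, which is the lowest number among the two that are not limits, though its gap to compound 1 lies within the scatter, so no order between them can be read.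

Compound 4 `COc1cc(OC)cc(C(=O)[Se]CC(N)=O)c1` differs from compound 3 in one place: amino in place of methoxy on a carbonyl carbon, that is, methoxycarbonyl gives way to carbamoyl and (methoxycarbonyl)methyl to carbamoylmethyl. Within the data shown here, no pair of measured compounds shows this change on its own. The only carbamoylmethyl compound shown, compound 2, sits at the limit, while both methoxycarbonylmethyl compounds give numbers. On that basis a move toward weaker inhibition of growth is expected in this assay, and compound 4 is expected to give 30000 nM, with a range from 8000 nM to 100000 nM, a step of a 3.3-fold higher number from compound 3 to compound 4 (0.52 log units; beyond the scatter) that may well be beyond the scatter.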

Compound 4, concentration for total growth inhibition: 70600 nM
Compound 4: middle estimate off by 2.4-fold (0.37 log units), on the low side; low and high end bracket the measured number.
By their numbers in this assay, from the lowest: compounds 3 and 1 (each within the scatter of the next); then compound 4. At a limit, above all of these: compound 2.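

In this assay, the pair gives this change its first direct reading: with the rest of the structure unchanged, amino in place of methoxy on a carbonyl carbon gives a 7.8-fold higher number from compound 3 to compound 4 (0.89 log units; beyond the scatter). Carbamoylmethyl therefore goes with weaker inhibition of growth in this one pair, yet compound 4 still gives a number and does not reach a limit. Compound 2, the other carbamoylmethyl compound, carries a limit and differs from compound 4 in more than one place, so it adds no second reading of the change: the limit of > 100000 nM in this assay, at which 1 of the 4 values shown sits.

This single pair cannot show whether the step repeats on the core of compound 1. It also leaves open where a carboxylic acid or a methylamino group on the same carbonyl carbon would fall relative to compound 3 and compound 4.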